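Adding a methyl group to compound 1

This account rests on a few compounds, and the source may have more. Where it says the series, first, only, none or still open, it means among the compounds named here.

Compound 1 `CC(C)C(/C=C1\NC(=O)NC1=O)c1ccc(-c2ccc3cccc(F)c3c2)[nH]c1=O`: > 3 h (a limit)
Compound 2 `CCC(CC)C(/C=C1\OC(=O)NC1=O)c1ccc(-c2ccc3cccc(F)c3c2)[nH]c1=O`: > 3 h (a limit)
Compound 3 `O=C1NC(=O)/C(=C/C2(c3ccc(-c4ccc5cccc(F)c5c4)[nH]c3=O)CC2)O1`: 2.48 h

All three were tested in an ADME assay on microsomes from liver (Homo sapiens) for metabolic stability; on this read-out higher numbers stand for a longer-lived compound and lower numbers for a shorter-lived compound. Compound 1 gives > 3 h, which is a limit of the assay and not a number, and it stands at the limit of > 3 h in this assay, at which 2 of the 3 values shown sit.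

Compound 4 `CC(C)C(/C=C1/C(=O)NC(=O)N1C)c1ccc(-c2ccc3cccc(F)c3c2)[nH]c1=O` differs from compound 1 by methyl in place of hydrogen on an amide-type nitrogen in a ring. Going by the values given here, no measured pair tests this change, so the expectation is loose. Compound 3 gives a measured value of 2.48 h. A small shortening is expected, possibly no more than the usual scatter, and the estimated step is an at least 1.2-fold lower number from compound 1 to compound 4 (0.07 log units; that floor lies within the scatter). For compound 4 the estimate is 2.5 h, with an expected range from 1.2 h to 3 h.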

Compound 4, half-life: > 3 h
Compound 4 was reported as a limit (the forecaster's own chance of this, stated with the estimate: 45%); middle value at least 1.2-fold (0.07 log units) away from the limit.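

Compound 1 and compound 4 both give a limit and not a number, so no step between them can be read: the limit of > 3 h in this assay, at which 3 of the 4 values shown sit.

The compounds shown leave open whether methyl in place of hydrogen on this ring nitrogen changes the half-life at all.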